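Ethoxy for methylamino at the toxicity limit

This account rests on a few compounds, and the source may have more. Where it says the series, first, only, none or still open, it means among the compounds named here.

Measured in a toxicity assay on HepG2 cells (Homo sapiens) for inhibition, read by resazurin assay, with a stated time of 24 h; on this read-out higher numbers stand for lower toxicity in this test and lower numbers for higher toxicity in this test (both values are limits of the assay):
Compound 1 `O=C(c1ncc([N+](=O)[O-])[nH]1)N1CCCC1` gives > 100000 nM as a limit
Compound 2 `CNC(=O)c1nc([N+](=O)[O-])cn1Cc1ccc(OC(F)(F)F)cc1` gives > 100000 nM as a limit

Compound 2 stands only on a limit, with > 100000 nM as its reading and no exact number behind it. Compound 3 `CCOC(=O)c1nc([N+](=O)[O-])cn1Cc1ccc(OC(F)(F)F)cc1` keeps the core of compound 2 and changes a single group. The change is ethoxy in place of methylamino on a carbonyl carbon, which reads as methylcarbamoyl to ethoxycarbonyl when cut one bond further out. Among the compounds with values here, no step between measured compounds is available, so the size of such a change in this assay has not been seen. The expectation leans on (the limit of > 100000 nM in this assay, at which 2 of the 2 values shown sit), which includes compound 2, and it is for no shift beyond the scatter in either direction. The expected move is an estimated a number no higher from compound 2 to compound 3 (the limit leaves the size open) and the reading may well come back once more as a limit only. In this assay the estimate for compound 3 is 100000 nM, with an expected range from 40000 nM to 250000 nM.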

Compound 3, half-maximal cytotoxic concentration: > 100000 nM
Compound 3: no number, only a limit; the forecaster's own chance of this, stated with the estimate: 75%; the middle value sits exactly at the limit.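

Within the data shown here, compound 3 returns only a limit, as compound 2 did, so no step from compound 2 to compound 3 can be read in this assay. The compounds shown leave open whether ethoxy in place of methylamino changes the reading at all, and at what concentration any of them would become toxic, with every reading resting on one limit: the limit of > 100000 nM in this assay, at which 3 of the 3 values shown sit.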